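The source may report more compounds than this note shows. Statements on the series, on what has been measured and on what is new or still open speak of the compounds shown alone.

Measured so far:
compound 1, `N=C(N)c1ccc(-c2ccc(-c3ccc(F)cc3)o2)o1`: 1600 nM
compound 2, `N=C(N)c1ccc(-c2ccc(-c3ccc(Cl)cc3)o2)o1`: 1660 nM
compound 3, `N=C(N)c1ccc(-c2ccc(-c3ccc(Cl)cc3)s2)s1`: 1780 nM

All three numbers come from a functional assay on MOLT-4 cells (Homo sapiens) for inhibition, read by sulforhodamine B assay, with a stated time of 48 h; a higher number here means a weaker inhibitor of growth, a lower number a stronger inhibitor of growth. In this assay compound 1 gives 1600 nM, compound 2 gives 1660 nM and compound 3 gives 1780 nM; the three values lie within the scatter of one another, so no order among them is claimed.

Compound 4, `N=C(N)c1ccc(-c2ccc(-c3ccc(F)cc3)s2)s1`, has not yet been measured. It is reached from compound 3 by fluoro in place of chloro on an aromatic carbon. The same change has been made once already within the series, from compound 2 to compound 1, (fluoro in place of chloro on an aromatic carbon), and there it produced a 1.0-fold lower number from compound 2 to compound 1 (0.02 log units; within the scatter). The position given for the change is the same, word for word, in both cases, so the two changes are taken as the same. Compound 3 and compound 2 carry the same group at the same position but are built on different cores; the difference between the two cores is not broken down here.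

Expectation: the change from compound 3 to compound 4 is expected to leave the number about where it stands, a 1.0-fold lower number from compound 3 to compound 4 (0.01 log units; within the scatter), and this rests on the earlier step of a 1.0-fold lower number from compound 2 to compound 1 (0.02 log units; within the scatter), which stayed within the scatter. For compound 4 in this assay the estimate is 1750 nM, expected to fall between 900 nM and 3500 nM.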

Compound 4, concentration for 50% growth inhibition: 1520 nM
For compound 4 the middle estimate is 1.2-fold (0.06 log units) above the measured one; measured number inside the range.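

In this assay, fluoro in place of chloro on an aromatic carbon gives a 1.2-fold lower number from compound 3 to compound 4 (0.07 log units; within the scatter), so the exchange leaves the number where it stands on this core. Set beside the same exchange on the other core, the step shows no difference that can be told from scatter, and in this narrow sense the result carries from one core to the other: the same change on two cores in this assay, a 1.0-fold lower number (0.02 log units; within the scatter) from compound 2 to compound 1 and a 1.2-fold lower number (0.07 log units; within the scatter) from compound 3 to compound 4, 1.1-fold (0.05 log units) apart, within the scatter of two such steps This agreement is one of two null steps, so it shows that the exchange stays silent on both cores in this assay, but it does not show that a change with a step beyond the scatter would carry across in the same way, nor does it extend past these two cores, this pair of halogens, this place on the six-membered ring, or this cell line.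

The compounds shown leave open whether a group further from chloro and fluoro at the same place, such as methoxy, trifluoromethyl, an amine or a carboxylic acid, would move the number in this assay. They also leave open whether such a group would behave alike on the two cores, which is the case where a comparison between cores would have something to detect.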